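Solubility at low pH: from compound 3 to compound 4

A few compounds are considered here, and "the series" means these few. Any claim that something is new, unique, unknown or untested is made for them only; others in the source may bear on it.

Of the compounds shown here, three sharing one core have been measured in a physicochemical assay for solubility, measured as kinetic solubility, at pH 2; on this read-out lower numbers stand for lower solubility and higher numbers for higher solubility. Compound 1, `CC(C)[C@H](C[C@H]1OC(=O)NC1=O)c1ccc(-c2ccc3cccc(F)c3c2)[nH]c1=O`, gives 24400 nM. Compound 2, `Cc1cc(C(/C=C2\OC(=O)NC2=O)C(C)C)c(=O)[nH]c1-c1ccc2cccc(F)c2c1`, gives 39400 nM. Compound 3, `CC(C)C(c1ccc(-c2ccc3cccc(F)c3c2)[nH]c1=O)C1C(=O)NC(=O)N1C`, gives 13600 nM. Among these three numbers compound 3 has the lowest; its gap to compound 1 is within the scatter of this assay, so the two cannot be ranked, while its gap to compound 2 is beyond the scatter, and compound 2 shows the higher solubility of the two.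

Compound 4, `CC(C)C(/C=C1/C(=O)NC(=O)N1C)c1ccc(-c2ccc3cccc(F)c3c2)[nH]c1=O`, is not yet measured. It differs from compound 3 in one place: a group of 9 heavy atoms (5 carbon, 2 nitrogen, 2 oxygen; one five-membered non-aromatic ring with 2 hetero atoms) in place of a group of 8 heavy atoms (4 carbon, 2 nitrogen, 2 oxygen; one five-membered non-aromatic ring with 2 hetero atoms), on a saturated chain carbon bound to an aromatic carbon and a saturated chain carbon. Both groups sit on a saturated chain carbon bound to an aromatic carbon and a saturated chain carbon, and both keep one hydrogen-bond donor and two hydrogen-bond acceptors. Within the data shown here, with no pair of measured compounds differing in exactly this way, no step size can be read from the data. The change is small in atom count, so the step of a 1.1-fold lower number from compound 3 to compound 4 (0.05 log units; within the scatter) is expected to stay within the scatter of this assay. Compound 4 is estimated at 12000 nM, with a likely range from 5000 nM to 30000 nM.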

Compound 4, solubility: 8300 nM
Compound 4: middle estimate off by 1.4-fold (0.16 log units), on the high side; the range from low to high includes it.
By their numbers in this assay, from the lowest: compounds 4, 3, 1 and 2 (each within the scatter of the next, the first and the last beyond it).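

Among these compounds, this is the first pair that differs in only one place, on a saturated chain carbon bound to an aromatic carbon and a saturated chain carbon: the 3-methyl-2,5-dioxoimidazolidin-4-yl group gives way to a group of 9 heavy atoms with 3 double bonds outside aromatic rings. In this assay, that exchange gives a 1.6-fold lower number from compound 3 to compound 4 (0.21 log units; within the scatter), so the two compounds cannot be ranked, and this one pair offers no sign that the exchange moves the read-out at this position. No measurement bears on why the two compounds fall so close together.

Compounds 1 and 2 differ from each other in more than one place, so no step can be read between them, and the contribution of the extra double bond on its own cannot be separated on the ring they carry. On these data alone, it also remains open whether a group of a different kind at this place, such as an amine or a carboxylic acid, would shift the number beyond the scatter.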